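Pyridin-3-ylmethyl for 4-methoxybenzyl on the shared core

The source may hold more compounds than are shown below. What is called first, only, known or untested is meant among the compounds shown, and "the series" means these compounds.

Measured so far in a functional assay on COLO 205 cells (Homo sapiens) for cytotoxicity; a higher number here means a weaker inhibitor, a lower number a stronger inhibitor:
compound 1 `COc1ccc(-n2nc(Nc3cc(C)[nH]n3)c3ccccc3c2=O)cc1`, 3700 nM
compound 2 `COc1ccc(Cn2nc(Nc3cc(C)[nH]n3)c3ccccc3c2=O)cc1`, 4200 nM

Compound 2 holds the highest of the two numbers in this assay; its nearest neighbour is compound 1, and the step of a 1.1-fold higher number from compound 1 to compound 2 (0.06 log units; within the scatter) lies within the scatter, so no order between compound 1 and compound 2 can be read from these numbers.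

Compound 3 `Cc1cc(Nc2nn(Cc3cccnc3)c(=O)c3ccccc23)n[nH]1` differs from compound 2 in one place: pyridin-3-yl in place of 4-methoxyphenyl on a saturated chain carbon bound to an aromatic nitrogen. Within the data shown here, the only measured step, a 1.1-fold higher number from compound 1 to compound 2 (0.06 log units; within the scatter), concerns the link between the aromatic nitrogen and the 4-methoxyphenyl group and left the number essentially unchanged. Among the measured compounds shown here, it does not touch the ring itself, and no measured pair exchanges the 4-methoxyphenyl ring for a pyridin-3-yl ring. For the measured compounds named here, the series therefore offers no direct precedent for this change.

Going by the values given here, with only one step on record, both within the scatter, the expectation for this assay is no step beyond the scatter. Compound 3 is therefore expected to give 4000 nM, within 1500 nM to 11000 nM, which means an expected step of a 1.1-fold lower number from compound 2 to compound 3 (0.02 log units; within the scatter).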

Compound 3, half-maximal inhibitory concentration: 4100 nM
For compound 3 the middle estimate is 1.0-fold (0.01 log units) below the measured one; the measured number falls inside the stated range.
By their numbers in this assay, from the lowest: compounds 1, 3 and 2 (each within the scatter of the next).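

In this assay, among these compounds, the exchange of the 4-methoxyphenyl ring for pyridin-3-yl on a saturated chain carbon bound to an aromatic nitrogen gives a 1.0-fold lower number from compound 2 to compound 3 (0.01 log units; within the scatter) and so puts the first ring exchange at this position on record, where earlier only the link had differed. A ring with 1 hetero atom and 6 heavy atoms thus reads the same here as the carbon-only ring with 8 heavy atoms and its methoxy group. The wider exchange, with link and ring both different, gives a 1.1-fold higher number from compound 1 to compound 3 (0.04 log units; within the scatter) in this assay, so all three groups on this aromatic nitrogen lie within the scatter of one another, and nothing at hand explains this flat reading.

Still open, on these data alone, is whether a carboxylic acid or an aliphatic amine in place of the aromatic ring, or a longer chain on the aromatic nitrogen, would give a step beyond the scatter in this assay. Also open, as far as these compounds go, is whether other places on the shared core, which all three compounds carry unchanged, respond any more strongly.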